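The source may hold more compounds than are shown below. What is called first, only, known or untested is meant among the compounds shown, and "the series" means these compounds.

Working notes on the series in a toxicity assay on Vero C1008 cells (Chlorocebus sabaeus) for cytotoxicity, read by neutral red uptake, with a stated time of 5 days; on this read-out lower numbers stand for higher toxicity in this test and higher numbers for lower toxicity in this test.

Three compounds share the core of compound 1 `CC(C)(C)c1ccc(N(C(=O)c2ccco2)C(C(=O)NC2CCCCC2)c2cccnc2)cc1` with a furoyl amide and a pyridyl-bearing carbon, and differ at the aryl group and at the amide-type nitrogen. In this assay compound 1 gives 18200 nM. Compound 2 `CC(C)(C)CC(C)(C)NC(=O)C(c1cccnc1)N(C(=O)c1ccco1)c1ccc(-c2ccccc2)cc1` gives 148000 nM in this assay. For the measured compounds named here, compound 3 `O=C(NC1CCCC1)C(c1cccnc1)N(C(=O)c1ccco1)c1ccc(-c2ccccc2)cc1` shows no number in this assay but only the limit of the measurement, > 200000 nM; this is the limit of > 200000 nM in this assay, at which 1 of the 3 values shown sits, and it is the only information on where compound 3 stands.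

Going by the values given here, one measured step bears on the amide-type nitrogen: an at least 1.3-fold higher number from compound 2 to compound 3 (0.13 log units; that floor lies within the scatter), a change that stayed within the scatter of repeated measurements.

Compound 4 `O=C(NC1CCCCC1)C(c1cccnc1)N(C(=O)c1ccco1)c1ccc(-c2ccccc2)cc1` differs from compound 3 in one place: cyclohexyl in place of cyclopentyl on an amide-type nitrogen. The change is a single added ring carbon at the same nitrogen where the measured step did not move the read-out beyond the scatter. For this assay the step expected is a number no higher from compound 3 to compound 4 (the limit leaves the size open), none beyond the scatter, with the caveat that compound 3 itself is known only as a limit. Compound 4 is estimated at 200000 nM in this assay, within a range from 90000 nM to 400000 nM, and a limit rather than a number is the more likely report.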

Compound 4, half-maximal cytotoxic concentration: 53500 nM
Beside the measured number, compound 4's estimate is 3.7-fold (0.57 log units) above it; the measured number lies below the stated range.
By their numbers in this assay, from the lowest: compound 1; then compound 4; then compound 2. At a limit, above all of these: compound 3.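

For the compounds shown here, at the amide-type nitrogen the read-out in this assay does move: cyclohexyl in place of cyclopentyl gives an at least 3.7-fold lower number from compound 3 to compound 4 (0.57 log units; beyond the scatter), and cyclohexyl in place of 1,1,3,3-tetramethylbutyl gives a 2.8-fold lower number from compound 2 to compound 4 (0.44 log units; beyond the scatter), so compound 4 stands lower than both of these, whereas the one earlier step at this nitrogen stayed within the scatter. Going by these compounds alone, with cyclohexyl held on that nitrogen, phenyl in place of tert-butyl on an aromatic carbon gives a 2.9-fold higher number from compound 1 to compound 4 (0.47 log units; beyond the scatter), the first single-place reading of this aryl substituent. The size of the step into compound 4 from the cyclopentyl compound stays open because compound 3 is known only as a limit: the limit of > 200000 nM in this assay, at which 1 of the 4 values shown sits.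

The compounds shown leave open whether the lower number belongs to cyclohexyl alone or continues with a larger ring such as cycloheptyl, and whether an amine or a carboxylic acid on that ring would change it. They also leave open whether phenyl in place of tert-butyl gives a similar step with another group on the amide-type nitrogen.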